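This account rests on a few compounds, and the source may have more. Where it says the series, first, only, none or still open, it means among the compounds named here.

Compound 2 `O=C(NCc1ccccc1)c1c(O)c2cccnc2n(-c2ccccc2)c1=O` stands second highest of the three numbers measured in a functional assay on the whole organism for inhibition, with Rattus norvegicus as the target, read by cytopathic effect and paw edema, at a dose of 100 mg/kg by the oral route (a higher number here means more inhibition at the dose given (going by the name of the read-out), a lower number less inhibition), where compound 2 gives 11.3%. Its nearest neighbour is compound 1 `O=C(Nc1ccccn1)c1c(O)c2cccnc2n(-c2ccccc2)c1=O`, which in this assay gives 14.6%, a gap of a number 3.3 percentage points lower from compound 1 to compound 2 (within the scatter) that lies within the scatter. Furthest away is compound 3 `O=C(Nc1ccc([N+](=O)[O-])cc1)c1c(O)c2cccnc2n(-c2ccccc2)c1=O`, which in this assay gives -25.8%; the step of a number 37.1 percentage points lower from compound 2 to compound 3 (beyond the scatter) is large and beyond the scatter, as is a number 40.4 percentage points lower from compound 1 to compound 3 (beyond the scatter).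

Compound 4 `O=C(Nc1cccc(Cl)c1)c1c(O)c2cccnc2n(-c2ccccc2)c1=O` differs from compound 2 in one place: 3-chlorophenyl in place of benzyl on an amide-type nitrogen. Among the compounds with values here, two measured steps bear on this. The step of a number 37.1 percentage points lower from compound 2 to compound 3 (beyond the scatter) also removes benzyl and puts in a substituted phenyl, though with a different substituent, and it fell strongly. The step of a number 3.3 percentage points lower from compound 1 to compound 2 (within the scatter), however, shows that an aromatic ring directly on that nitrogen need not differ from benzyl beyond the scatter. The outlook is therefore uncertain, leaning toward a small fall.

Compound 4 is expected to give an inhibition of 0% in this assay, within -25% to 22%, which means an estimated step of a number 11.3 percentage points lower from compound 2 to compound 4 (beyond the scatter).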

Compound 4, a percentage reported as inhibition, in the whole organism at one dose (the size of the read-out at that dose, not a potency): 13.4%
Compound 4: middle estimate off by 13.4 percentage points, on the low side; the measured number falls inside the stated range.
By their numbers in this assay, from the lowest: compound 3; then compounds 2, 4 and 1 (each within the scatter of the next).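

In this assay, the step of a number 2.1 percentage points higher from compound 2 to compound 4 (within the scatter) and the step of a number 1.2 percentage points lower from compound 1 to compound 4 (within the scatter) show that 3-chlorophenyl on the amide-type nitrogen cannot be told apart from either benzyl or pyridin-2-yl. A substituted phenyl on that nitrogen therefore does not by itself bring the fall seen earlier: the step of a number 39.2 percentage points higher from compound 3 to compound 4 (beyond the scatter) separates two such rings, and among the four compounds only compound 3, with 4-nitrophenyl, stands apart. No measurement at hand accounts for this difference.

As far as these compounds go, whether compound 3 stands apart for its nitro group or for the place of its substituent stays open, and 3-nitrophenyl or 4-chlorophenyl on the same nitrogen would separate the two. From the compounds shown here alone, how a phenyl ring carrying a carboxylic acid or an amine would read, or a phenethyl group in place of benzyl, is also open.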